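This account rests on a few compounds, and the source may have more. Where it says the series, first, only, none or still open, it means among the compounds named here.

Measured so far in a functional assay on CCRF-CEM cells (Homo sapiens) for inhibition (a higher number here means a weaker inhibitor of growth, a lower number a stronger inhibitor of growth), are these compounds:
- compound 1 `NC(=O)c1cc(Cl)ccc1NC(=O)COc1ccccc1` gives 3070 nM
- compound 2 `NC(=O)c1cc(I)ccc1NC(=O)COc1ccccc1` gives 382 nM

Compound 2 holds the lower of the two numbers. Compound 3 `COc1ccc(NC(=O)COc2ccccc2)c(C(N)=O)c1` differs from it by methoxy in place of iodo on an aromatic carbon on the carbon meta to a carbamoyl group and para to a large group. Among the compounds with values here, the one measured step at this place is an 8.0-fold lower number from compound 1 to compound 2 (0.91 log units; beyond the scatter) (iodo in place of chloro), which lies beyond the scatter. Methoxy itself is untested here, so a rise of similar size in this assay is only an expectation, estimated as a 6.5-fold higher number from compound 2 to compound 3 (0.82 log units; beyond the scatter) here. For compound 3 the expected value is 2500 nM with an estimated range of 700 nM to 9000 nM in this assay.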

Compound 3, concentration for 50% growth inhibition: 487 nM
Compound 3: the middle estimate sits 5.1-fold (0.71 log units) above what was measured; measured number outside the range, below it.
By their numbers in this assay, from the lowest: compounds 2 and 3 (each within the scatter of the next); then compound 1.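

In this assay the low number at this carbon proves not to be peculiar to iodo: methoxy gives a 1.3-fold higher number from compound 2 to compound 3 (0.11 log units; within the scatter) and so matches it within the scatter. Methoxy also keeps the gain over chloro, with a 6.3-fold lower number from compound 1 to compound 3 (0.80 log units; beyond the scatter) beyond the scatter. Nothing available here accounts for chloro standing apart from these two groups. From the compounds shown here alone, whether an amine, a nitrile or a longer ether chain such as ethoxy would also keep the number this low remains open, as does the effect of a bare hydrogen at this carbon.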